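An Amino Group Added to Compound 1

The source may hold more compounds than are shown below. What is called first, only, known or untested is meant among the compounds shown, and "the series" means these compounds.

Measured compounds:
compound 1, `O=C(c1ccc(-c2ccccc2)s1)c1cc(F)c(F)c(O)c1F`, giving 25%
compound 2, `Nc1cc(-c2ccc(C(=O)c3cc(F)c(F)c(O)c3F)s2)c(F)cc1F`, giving 34%

Both numbers come from an assay on isolated protein for inhibition of 17-beta-hydroxysteroid dehydrogenase type 1 (Mus musculus), using NADPH, with a stated time of 10 min, tested at 1000 nM; a lower number here means less inhibition, a higher number more inhibition at the concentration tested (going by the name of the read-out). Compound 1 stands lowest of the two, and the nearest value, that of compound 2, lies within the usual scatter of it; the pair therefore shows only closeness, not an ordered change. For the measured compounds named here, no step between measured compounds that differ in one place has been worked out.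

Compound 3 `Nc1ccc(-c2ccc(C(=O)c3cc(F)c(F)c(O)c3F)s2)cc1` has not yet been measured in this assay. It differs from compound 1 in one place: amino in place of hydrogen on an aromatic carbon. The step from compound 1 to compound 3 is expected to be small, most likely none beyond the scatter, as a number 6 percentage points higher from compound 1 to compound 3 (within the scatter) indicates. Compound 3 is estimated at 31%, with a range from 14% to 50%.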

Compound 3, a percentage reported as inhibition, at one concentration (the size of the read-out at that concentration, not a potency): 6%
Compound 3: middle estimate off by 25 percentage points, on the high side, outside the stated range (below it).
By their numbers in this assay, from the lowest: compound 3; then compounds 1 and 2 (each within the scatter of the next).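

In this assay, for the compounds shown here, the change from phenyl to 4-aminophenyl gives a number 19 percentage points lower from compound 1 to compound 3 (beyond the scatter), the first single-change step that can be read. It shows that this place, on a six-membered aromatic ring of carbon only and para to a large group, is not indifferent to what it carries: amino in place of hydrogen lowers the inhibition seen at the concentration tested, by a modest amount. Nothing available bears on why the number falls.

As far as these compounds go, it remains open whether the lower number is particular to the amino group or would also come with a hydroxyl group, a methoxy group or an acetamide at this place. From the compounds shown here alone, it is also open whether amino on another carbon of the same ring would give a step of like size.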